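Permeability notes: amide substituent swap from compound 1

This account rests on a few compounds, and the source may have more. Where it says the series, first, only, none or still open, it means among the compounds named here.

On an ADME assay for permeability (on this read-out higher numbers stand for higher permeability and lower numbers for lower permeability), compound 1 `CNC(=O)c1cc(C(=O)N[C@H]2[C@@H]3COC[C@@H]32)c([C@@H](C)c2ccccc2)o1` gives 200 nm/s, level at the digits shown with compound 2 `CCC(=O)c1c[nH]c(C(=O)NC)c1` at 200 nm/s; together these are the highest of three numbers. Compound 3 `CNC(=O)c1cc(C(=O)N[C@H]2CC[C@H](O)CC2)c([C@@H](C)c2cccc(OC)c2)o1` is furthest off at 44 nm/s, a gap beyond the scatter, though it differs from compound 1 in more than one place.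

Compound 4 `CNC(=O)c1cc(C(=O)N[C@H]2[C@@H]3C[C@@H](O)C[C@@H]32)c([C@@H](C)c2ccccc2)o1` follows from compound 1 by a group of 7 heavy atoms (6 carbon, 1 oxygen; one three-membered non-aromatic ring of carbon only, one five-membered non-aromatic ring of carbon only) in place of a group of 6 heavy atoms (5 carbon, 1 oxygen; one three-membered non-aromatic ring of carbon only, one five-membered non-aromatic ring with 1 hetero atom), on an amide-type nitrogen. Among the compounds with values here, no single-site step in this assay is available for comparison. A drop beyond the scatter is expected, a 2.0-fold lower number from compound 1 to compound 4 (0.30 log units; within the scatter), of moderate size. Compound 4 is estimated at 100 nm/s in this assay, within roughly 40 nm/s to 200 nm/s.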

Compound 4, apparent permeability: 45 nm/s
Compound 4: the middle estimate sits 2.2-fold (0.35 log units) above what was measured; measured number inside the range.
By their numbers in this assay, from the lowest: compounds 3 and 4 (each within the scatter of the next); then compounds 1 and 2 (each within the scatter of the next).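

In this assay, within the data shown here, the first single-site step at this amide-type nitrogen is a 4.4-fold lower number from compound 1 to compound 4 (0.65 log units; beyond the scatter) and lies beyond the scatter. The entering group has 1 hydrogen-bond donor where the leaving group has 0, and its five-membered ring is carbon only, so this one step does not separate these two differences. Nothing available gives a cause for the step.

As far as these compounds go, whether the step follows the donor or the ring change stays open. A methoxy group or an amine on the carbon-only ring would help separate them.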